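Lengthening the fluorinated tail by one carbon

This account rests on a few compounds, and the source may have more. Where it says the series, first, only, none or still open, it means among the compounds named here.

Measured compounds:
- compound 1, `C[C@]1(c2ccc(O)cc2)CSc2cc(O)ccc2[C@H]1CCCCCCCCC(CCCC(F)(F)C(F)(F)F)C(=O)O`: 41%
- compound 2, `C[C@]1(c2ccc(O)cc2)CSc2cc(O)ccc2[C@H]1CCCCCCCCC(CCCC(F)(F)C(F)(F)C(F)(F)C(F)(F)F)C(=O)O`: 61%

In a functional assay on the whole organism for antagonist activity, with Mus musculus as the target, at a dose of 3 mg/kg by the oral route (on this read-out lower numbers stand for a weaker effect and higher numbers for a stronger effect at the one dose given), compound 1 gives 41%, the lower of the two numbers seen so far. Compound 2 shows a number 20 percentage points higher from compound 1 to compound 2 (beyond the scatter), a change beyond the scatter that came with a longer fluorinated end on the chain.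

Compound 3, `C[C@]1(c2ccc(O)cc2)CSc2cc(O)ccc2[C@H]1CCCCCCCCC(CCCCC(F)(F)C(F)(F)F)C(=O)O`, differs from compound 1 by 2,2,3,3,3-pentafluoropropyl in place of 1,1,2,2,2-pentafluoroethyl on a saturated chain carbon, four bonds along the chain from a carbonyl carbon. The fluorinated end is unchanged in kind; the chain carrying it simply grows by one carbon.

Going by the values given here, the only measured step that bears on this is the one from compound 1 to compound 2, where a longer fluorinated tail gave a modest rise. Extending the chain by a single carbon is a smaller change, so only a small upward step is expected, and it may stay within the scatter. The step from compound 1 to compound 3 is estimated at a number 8 percentage points higher from compound 1 to compound 3 (within the scatter). Compound 3 is therefore expected to give 49%, between 30% and 68%.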

Compound 3, a percentage reported as inhibition, in the whole organism at one dose (the size of the read-out at that dose, not a potency): 69%
Compound 3: middle estimate off by 20 percentage points, on the low side; measured number outside the range, above it.
By their numbers in this assay, from the lowest: compound 1; then compounds 2 and 3 (each within the scatter of the next).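

Placing 2,2,3,3,3-pentafluoropropyl in place of 1,1,2,2,2-pentafluoroethyl on a saturated chain carbon, four bonds along the chain from a carbonyl carbon, gives a number 28 percentage points higher from compound 1 to compound 3 (beyond the scatter) in this assay at the one dose given. Both groups carry five fluorine atoms, so in this pair the higher number comes with one added carbon and no added fluorine, whereas the step to compound 2 added both. No measurement shown gives a reason for this rise.

As far as these compounds go, it remains open whether 3,3,4,4,4-pentafluorobutyl, the same change cut one bond further out, would raise the number again. A butyl chain with no fluorine would test whether the fluorine atoms matter at all at this position.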